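The compounds below may be only part of what the source reports. "The series", "measured", "known", "first", "only" and "open" are said of these compounds alone.

Working notes on the amide series sharing the core of compound 1 `CCCC(=O)Nc1c(C(O)(C(F)(F)F)C(F)(F)F)ccc2ccccc12`, measured in an assay on LtK cells with ATP-sensitive inward rectifier potassium channel 11 (Homo sapiens) as the target; a higher number here means that more compound is needed for the effect, a lower number that less compound is needed.

Compound 1 gives 131 nM, the lowest of the two numbers available. Compound 2 `CCC(CC)C(=O)Nc1c(C(O)(C(F)(F)F)C(F)(F)F)ccc2ccccc12` gives 4340 nM, which is a 33-fold higher number from compound 1 to compound 2 (1.52 log units; beyond the scatter). Compound 3 `CCCC(C)C(=O)Nc1c(C(O)(C(F)(F)F)C(F)(F)F)ccc2ccccc12` returns only a limit of the assay, > 10000 nM, so its value is known only as a boundary (the limit of > 10000 nM in this assay, at which 1 of the 3 values shown sits). Measured against that boundary, the change to compound 3 is an at least 76-fold higher number from compound 1 to compound 3 (1.88 log units; beyond the scatter), and going from compound 2 to compound 3 is an at least 2.3-fold higher number from compound 2 to compound 3 (0.36 log units; beyond the scatter).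

Compound 4 `O=C(Nc1ccc(Cl)cc1)Nc1c(C(O)(C(F)(F)F)C(F)(F)F)ccc2ccccc12` is not yet measured. Relative to compound 1 the change is (4-chlorophenyl)amino in place of propyl on a carbonyl carbon. Among the compounds with values here, no measured step covers this change: the two known steps on the carbonyl carbon each replaced propyl with a branched alkyl and both raised the number, one of them to the limit. The present change is of a different kind, replacing the chain with a ring-bearing amine, and nothing in the series shows how such a group behaves. Taking the earlier sensitivity of the carbonyl substituent as the only guide, a higher number than for compound 1 is expected, in this assay of a size of about a 6.9-fold higher number from compound 1 to compound 4 (0.84 log units; beyond the scatter). Compound 4 is therefore estimated at 900 nM, with a plausible range from 120 nM to 7000 nM.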

Compound 4, half-maximal effective concentration: 276 nM
Estimate against measurement, compound 4: 3.3-fold (0.51 log units) above, and the stated range covers the measured number.
By their numbers in this assay, from the lowest: compound 1; then compound 4; then compound 2. At a limit, above all of these: compound 3.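

On the carbonyl carbon, the earlier replacements of propyl were all branched alkyl groups and all gave large rises, whereas (4-chlorophenyl)amino, with its six-membered aromatic ring and hydrogen-bond donor, costs much less in this assay: a 2.1-fold higher number from compound 1 to compound 4 (0.32 log units; beyond the scatter), a modest step. This position therefore does not respond badly to every replacement of propyl, and the same group stands well clear of the pentan-3-yl amide, with a 16-fold lower number from compound 2 to compound 4 (1.20 log units; beyond the scatter). Compound 3 is known only as a limit of the assay, which makes an at least 36-fold lower number from compound 3 to compound 4 (1.55 log units; beyond the scatter) a large step whose true size stays unknown, and that boundary is shared by none of the other compounds: the limit of > 10000 nM in this assay, at which 1 of the 4 values shown sits.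

The change to compound 4 brings in the amino nitrogen, the aromatic ring and the chlorine all at once, and the compounds shown do not separate their contributions; phenylamino without the chlorine, or benzyl without the nitrogen, would begin to do so. As far as these compounds go, it also remains open how an unbranched pentyl chain on the carbonyl carbon would compare with propyl, so the rises seen for compound 2 and compound 3 cannot yet be assigned to branching rather than to chain length.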